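The compounds below may be only part of what the source reports. "The series", "measured", "known", "first", "only" and "open" are said of these compounds alone.

Measured so far:
compound 1, `NCc1csc(NC(=O)c2ccc(Cl)cc2)n1`: 25 ug/mL
compound 2, `Cc1csc(NC(=O)c2cc(C(C)(C)C)nn2Cc2ccccc2)n1`: < 1.6 ug/mL

In a physicochemical assay for solubility, read by nephelometry, measured as kinetic solubility, at pH 6.5 (on this read-out higher numbers stand for higher solubility and lower numbers for lower solubility), compound 1 gives 25 ug/mL. Compound 2 is reported only as a limit of the assay, < 1.6 ug/mL, and not as a number. Compound 2 thus sits at the limit of < 1.6 ug/mL in this assay, at which 1 of the 2 values shown sits. Going by the values given here, compound 1 and compound 2 differ in more than one place, so no single step between them is counted; the two values show only that compound 1 has a number and compound 2 a limit.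

Compound 3, `CC(C)(C)c1cc(C(=O)Nc2ccccc2)n(Cc2ccccc2)n1`, is the next compound for this assay and differs from compound 2 in one place: phenyl in place of 4-methyl-1,3-thiazol-2-yl on an amide-type nitrogen. Among the compounds with values here, no measured step covers this exchange, so the expectation rests on compound 2 alone.

The expected step that the limit leaves unreadable from compound 2 to compound 3 is small, at most a slight lowering and likely none beyond the usual scatter, since compound 2 already gives < 1.6 ug/mL as a limit. Compound 3 is therefore estimated at 1.2 ug/mL, within a range from 0.4 ug/mL to 4 ug/mL, with a fair chance that the assay again reports only a limit.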

Compound 3, solubility: 1.6 ug/mL
For compound 3 the middle estimate is 1.3-fold (0.12 log units) below the measured one; the range from low to high includes it.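

In this assay compound 3, with phenyl in place of 4-methyl-1,3-thiazol-2-yl on an amide-type nitrogen, gives a number, 1.6 ug/mL. Compound 2 is reported only as a limit of the assay, < 1.6 ug/mL. This is the first reading at this position that is a number rather than a limit, and the exchange of a five-membered aromatic ring with 2 hetero atoms for a six-membered aromatic ring of carbon only gives a number no lower from compound 2 to compound 3 (the limit leaves the size open) but the size of the step cannot be read: the limit of < 1.6 ug/mL in this assay, at which 1 of the 3 values shown sits.

Going by these compounds alone, whether the true value of compound 2 lies close to that of compound 3 or well apart from it stays open, and compound 1 differs from both in more than one place, so it gives no step at this position. From the compounds shown here alone, how a phenyl carrying an aminomethyl group or a carboxylic acid would read in this assay also stays open, so nothing can yet be said about the trend at this position beyond this single exchange.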